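A few compounds are considered here, and "the series" means these few. Any claim that something is new, unique, unknown or untested is made for them only; others in the source may bear on it.

Measured compounds:
Compound 1, `CCn1c(C(=O)NCc2ccc(OC)cc2)ccc1C(CC)(CC)c1ccc(C#CC(O)(CC)CC)c(C)c1`: in an assay on cells for agonist activity at vitamin D3 receptor (Homo sapiens), read by microscopy (a lower number here means that less compound is needed, a higher number that more compound is needed for the effect), compound 1 gives > 50 nM, which is a limit of the assay.
Compound 2, `C#CCCOC(=O)c1ccc(C(CC)(CC)c2ccc(C#CC(O)(CC)CC)c(C)c2)n1CC`: in this assay compound 2 gives > 50 nM, again a limit of the assay.
Compound 3, `CCn1c(C(=O)NCC(=O)O)ccc1C(CC)(CC)c1ccc(C#CC(O)(CC)CC)c(C)c1`: in this assay compound 3 gives 9.36 nM.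

Compound 2 therefore stands at the limit, where two of the three values sit (the limit of > 50 nM in this assay, at which 2 of the 3 values shown sit); only compound 3 carries a number. Compound 4, `CCn1c(C(=O)NCCC(=O)O)ccc1C(CC)(CC)c1ccc(C#CC(O)(CC)CC)c(C)c1`, is not yet measured. It differs from compound 2 in one place: (2-carboxyethyl)amino in place of (but-3-yn-1-yl)oxy on a carbonyl carbon. The measured step that bears most directly on this is an at least 5.3-fold lower number from compound 2 to compound 3 (0.72 log units; beyond the scatter), in which (carboxymethyl)amino replaced the same (but-3-yn-1-yl)oxy on the carbonyl carbon; compound 4 brings in (2-carboxyethyl)amino in that same place. Both an at least 5.3-fold lower number from compound 1 to compound 3 (0.72 log units; beyond the scatter) and that step point the same way, while a step that the two limits leave unreadable from compound 1 to compound 2 adds nothing readable. One therefore expects a step down in this assay of about the same size, an at least 3.3-fold lower number from compound 2 to compound 4 (0.52 log units; beyond the scatter). Compound 4 is accordingly estimated at 15 nM, with a range from 5 nM to 50 nM.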

Compound 4, half-maximal effective concentration: 293 nM
The estimate for compound 4 lay 20-fold (1.29 log units) below the measured number, and the stated range ends below it.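

In this assay, the chain on the carbonyl carbon proves sensitive to its length: going from (carboxymethyl)amino to (2-carboxyethyl)amino gives a 31-fold higher number from compound 3 to compound 4 (1.50 log units; beyond the scatter). A terminal carboxy group alone therefore does not secure the number seen for compound 3, which needs the least compound of the four shown. The steps from compound 1 and compound 2 to compound 4 cannot be read: the limit of > 50 nM in this assay, at which 2 of the 4 values shown sit.

The compounds shown leave open how a still longer chain ending in carboxy would fare in this place. They also leave open whether a hydroxyl or a primary amide could stand in for the carboxy group on the chain of compound 3.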